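A few compounds are considered here, and "the series" means these few. Any claim that something is new, unique, unknown or untested is made for them only; others in the source may bear on it.

Compound 1 `COc1cc(-c2nn(-c3cccc(NC(=O)c4cccc(C(F)(F)F)c4)c3)cc2-c2ccncc2)ccc1Cl` was tested in a functional assay on SK-MEL-5 cells (Homo sapiens) for inhibition, read by sulforhodamine B assay, with a stated time of 48 h (a lower number here means that less compound is tolerated, a higher number that more compound is tolerated), where compound 1 gives 40600 nM. For the measured compounds named here, that is the higher of the two numbers measured so far: compound 2 `O=C(Nc1cccc(-n2cc(-c3ccncc3)c(-c3ccc(Cl)c(O)c3)n2)c1)Nc1cc(C(F)(F)F)cc(C(F)(F)F)c1`, which carries a urea linker and a differently substituted core, gives 2620 nM, a gap that lies beyond the usual scatter. Compound 3 `COc1cc(-c2nn(-c3cccc(NC(=O)Nc4ccc(Cl)c(C(F)(F)F)c4)c3)cc2-c2ccncc2)ccc1Cl` has not yet been measured. It differs from compound 1 in one place: (4-chloro-3-(trifluoromethyl)phenyl)amino in place of 3-(trifluoromethyl)phenyl on a carbonyl carbon. The amide of compound 1 thus becomes a urea, as found in compound 2. Going by the values given here, no direct step between measured compounds isolates this change, so the expectation rests on compound 2 alone, whose 2620 nM is the lower of the two numbers. A downward step is expected, with a 6.8-fold lower number from compound 1 to compound 3 (0.83 log units; beyond the scatter), although it may still fall within the scatter. Compound 3 is therefore estimated at 6000 nM, with a likely range from 1500 nM to 25000 nM.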

Compound 3, concentration lethal to 50% of the cells: 10400 nM
For compound 3 the middle estimate is 1.7-fold (0.24 log units) below the measured one; the measured number falls inside the stated range.
By their numbers in this assay, from the lowest: compound 2; then compound 3; then compound 1.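

For the compounds shown here, replacing 3-(trifluoromethyl)phenyl on the carbonyl carbon with (4-chloro-3-(trifluoromethyl)phenyl)amino gives the first single-place comparison. In this assay this change gives a 3.9-fold lower number from compound 1 to compound 3 (0.59 log units; beyond the scatter) and so is a modest step that still lies beyond the usual scatter, showing that the number responds to a change at this place while the core of compound 1 stays the same. No measurement at hand explains the step.

Going by these compounds, the amino nitrogen and the chlorine enter together, so it stays open how much of the step belongs to each of them. Also open, on these data alone, is how the number would move with a fluorine or a nitrile in place of that chlorine, or with a methylene in place of that amino nitrogen.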